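Fixing the stereocentre of compound 3

This account rests on a few compounds, and the source may have more. Where it says the series, first, only, none or still open, it means among the compounds named here.

Compound 1 `COc1ccccc1OCCNC[C@H](O)COc1c(OC)ccc2[nH]ccc12` gives 11.3 nM in an assay on membranes from Cerebral cortex (strain Wistar) for displacement of a labelled ligand from Adrenergic receptor alpha-1 (Rattus norvegicus), read by scintillation counting; on this read-out lower numbers stand for stronger inhibition and higher numbers for weaker inhibition. Compound 2 `COc1ccccc1OCCNCC(O)COc1cccc2[nH]ccc12` gives 89.8 nM. Compound 3 `COc1ccccc1OCCNCC(O)COc1ccc(OC)c2[nH]ccc12` gives 75.8 nM.

Compound 3 stands second highest of the three numbers; compound 2 is nearest and within the scatter, while compound 1 gives a far lower number. Compound 4 `COc1ccccc1OCCNC[C@@H](O)COc1ccc(OC)c2[nH]ccc12` differs from compound 3 only in that (the two compounds have the same atoms and bonds; at least one stereo element is drawn with a configuration in one of them and without one in the other: 1 of 1 stereo elements differ; a stereocentre at a saturated chain carbon is drawn without a configuration in compound 3 and R in compound 4). Within the data shown here, the one measured step, a 1.2-fold lower number from compound 2 to compound 3 (0.07 log units; within the scatter), concerns a methoxy and not a stereocentre, so no measured pair isolates the configuration. Compound 1 carries a drawn configuration and a low number, but its methoxy sits elsewhere, so its value alone does not settle the point. The expected step is a 1.5-fold higher number from compound 3 to compound 4 (0.16 log units; within the scatter), and compound 4 is estimated at 110 nM, with a wide range from 40 nM to 350 nM.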

Compound 4, inhibition constant: 60.9 nM
Compound 4: middle estimate off by 1.8-fold (0.26 log units), on the high side; the range from low to high includes it.
By their numbers in this assay, from the lowest: compound 1; then compounds 4, 3 and 2 (each within the scatter of the next).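

Among these compounds, compound 3 and compound 4 form the first measured pair that isolates the stereocentre at a saturated chain carbon. In this assay, drawing that centre as R gives a 1.2-fold lower number from compound 3 to compound 4 (0.10 log units; within the scatter), so this change shows no effect that can be told from the scatter. The comparison rests on one difference only: the fact that one of compounds 3 and 4 is drawn with a defined configuration and the other without, at the place where they differ

The compounds shown leave open how the S configuration at this carbon would read. Also open, from the compounds shown here alone, is whether an ethoxy group in place of the methoxy would change the number.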